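Series notes: benzyl for cyclohexyl on the terminal amide

A few compounds are considered here, and "the series" means these few. Any claim that something is new, unique, unknown or untested is made for them only; others in the source may bear on it.

Measured in an assay on HeLa cells for displacement of a labelled ligand from adenosine receptor A3 (Homo sapiens), read by fluorescence polarization, with a stated time of 30 min; a lower number here means a stronger inhibitor, a higher number a weaker inhibitor:
compound 1 `COc1ccc(-c2cc(NC(=O)COCC(=O)NCC(=O)NCc3ccccc3)nc(-c3ccc(OC)cc3)n2)cc1`: 64600 nM
compound 2 `COc1ccc(-c2cc(NC(=O)COCC(=O)N3CCN(CC(=O)NC4CCCCC4)CC3)nc(-c3ccc(OC)cc3)n2)cc1`: 18300 nM

Compound 2 has the lowest of the two numbers; compound 1 sits at a higher number, beyond the scatter. Compound 3 `COc1ccc(-c2cc(NC(=O)COCC(=O)N3CCN(CC(=O)NCc4ccccc4)CC3)nc(-c3ccc(OC)cc3)n2)cc1` differs from compound 2 by benzyl in place of cyclohexyl on an amide-type nitrogen. Among the measured compounds shown here, no measured pair shows this change on its own, so no size can be read from the data; the step is expected to be a 1.2-fold higher number from compound 2 to compound 3 (0.08 log units; within the scatter), none beyond the scatter. Compound 3 is expected at 22000 nM, with a range from 8000 nM to 60000 nM.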

Compound 3, inhibition constant: 9300 nM
Estimate against measurement, compound 3: 2.4-fold (0.37 log units) above; measured number inside the range.
By their numbers in this assay, from the lowest: compounds 3 and 2 (each within the scatter of the next); then compound 1.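

Among the compounds shown here, on the amide-type nitrogen, benzyl in place of cyclohexyl gives the first single-place step: in this assay the change reads a 2.0-fold lower number from compound 2 to compound 3 (0.29 log units; within the scatter) and stays within the scatter. At this place, the assay therefore does not separate the aromatic ring of benzyl from the non-aromatic ring of cyclohexyl. Nothing available accounts for this result. Still open, as far as these compounds go, is how a phenethyl group or an open-chain alkyl group would read on this nitrogen. Also open, from the compounds shown here alone, is how a benzyl group carrying an amine or a carboxylic acid would read there.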